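This account rests on a few compounds, and the source may have more. Where it says the series, first, only, none or still open, it means among the compounds named here.

Compound 1 `COc1ccc(-c2[nH]c3ccc(C)cc3c2C=O)cc1`: 140 nM
Compound 2 `CCCCc1ccc2[nH]c(-c3ccc(OC)cc3)c(C=O)c2c1`: 22 nM
Compound 3 `CCCCc1ccc2[nH]c(-c3ccc(F)cc3)c(C=O)c2c1`: 200 nM

These values come from a functional assay on MCF7 cells (Homo sapiens) for antiproliferative activity, with a stated time of 5 days; a lower number here means a stronger inhibitor, a higher number a weaker inhibitor. Among the three, compound 2 has the lowest number, 22 nM. Compound 4 `CCCCc1ccc2[nH]c(-c3ccc(OC)cc3)c(/C=N\C)c2c1` departs from it at a single place: a group of 3 heavy atoms (2 carbon, 1 nitrogen; no ring) in place of a group of 2 heavy atoms (1 carbon, 1 oxygen; no ring), on an aromatic carbon. Going by the values given here, no measured step changes the formyl group, so the evidence is only indirect. Two changes elsewhere on the molecule give a sense of scale, a 6.4-fold lower number from compound 1 to compound 2 (0.80 log units; beyond the scatter) and a 9.1-fold higher number from compound 2 to compound 3 (0.96 log units; beyond the scatter), both modest and beyond the scatter. In this assay a smaller step than these is expected, more likely toward a higher number, given the low standing of compound 2 at 22 nM. The expected step is a 1.8-fold higher number from compound 2 to compound 4 (0.26 log units; within the scatter). For compound 4 the estimate is 40 nM, with an expected range from 10 nM to 200 nM.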

Compound 4, half-maximal inhibitory concentration: 27 nM
Compound 4: middle estimate off by 1.5-fold (0.17 log units), on the high side; the measured number falls inside the stated range.
By their numbers in this assay, from the lowest: compounds 2 and 4 (each within the scatter of the next); then compounds 1 and 3 (each within the scatter of the next).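

In this assay, going by these compounds alone, the first measured change at this position, putting a group of 3 heavy atoms (2 carbon, 1 nitrogen) in place of the formyl group, gives a 1.2-fold higher number from compound 2 to compound 4 (0.09 log units; within the scatter). Within the data shown here, the earlier compounds all carry the formyl group, so only this step shows that it can be replaced here without a change beyond the scatter. No measured evidence bears on why the two groups read alike.

From the compounds shown here alone, whether a nitrile, an amine or a carboxylic acid on this carbon would also hold the number remains open. So does whether the same replacement would read alike with fluoro in place of methoxy.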